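A few compounds are considered here, and "the series" means these few. Any claim that something is new, unique, unknown or untested is made for them only; others in the source may bear on it.

Measured compounds, with their readings in an ADME assay on cells (Peritoneal macrophage, Mus musculus, strain Balb/c) for cytotoxicity, read by resazurin assay, with a stated time of 72 h; on this read-out lower numbers stand for higher toxicity in this test and higher numbers for lower toxicity in this test:
compound 1 `CC1(Cc2cccc(/C(N)=N/O)c2)CC(S(=O)(=O)c2ccc(F)cc2)=C(c2ccc(/C(N)=N/O)cc2)O1`, 50200 nM
compound 2 `CC1(Cc2ccccc2C(F)(F)F)CC(S(=O)(=O)c2ccc(F)cc2)=C(c2ccc(/C(N)=N/O)cc2)O1`, 105000 nM
compound 3 `CC1(Cc2cc(C(F)(F)F)cc(C(F)(F)F)c2)CC(S(=O)(=O)c2ccc(F)cc2)=C(c2ccc(/C(N)=N/O)cc2)O1`, 43100 nM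

Compound 1 stands second highest of the three numbers; compound 3 lies within the scatter of it, and compound 2 is the only one that differs from it beyond the scatter. Compound 4 `COc1cc(CC2(C)CC(S(=O)(=O)c3ccc(F)cc3)=C(c3ccc(/C(N)=N/O)cc3)O2)cc(OC)c1OC` is not yet measured; it differs from compound 1 by a group of 12 heavy atoms (9 carbon, 3 oxygen; one six-membered aromatic ring of carbon only) in place of a group of 10 heavy atoms (7 carbon, 2 nitrogen, 1 oxygen; one six-membered aromatic ring of carbon only), on a saturated chain carbon bound to a saturated ring carbon. Among the compounds with values here, the one step that bears on this place is a 2.1-fold higher number from compound 1 to compound 2 (0.32 log units; beyond the scatter), a modest rise after exchange of the same leaving group for another ring. Compound 3 carries yet another ring at this place and reads close to compound 1. A change of the same kind in compound 4 is therefore expected to give no more than a small step in this assay, a 1.1-fold higher number from compound 1 to compound 4 (0.04 log units; within the scatter). Compound 4 is estimated at 55000 nM, in a range from 25000 nM to 120000 nM.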

Compound 4, half-maximal cytotoxic concentration: 92300 nM
Compound 4: middle estimate off by 1.7-fold (0.22 log units), on the low side; the range from low to high includes it.
By their numbers in this assay, from the lowest: compounds 3, 1, 4 and 2 (each within the scatter of the next, the first and the last beyond it).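

In this assay, placing 3,4,5-trimethoxyphenyl on the saturated chain carbon bound to a saturated ring carbon gives a 1.8-fold higher number from compound 1 to compound 4 (0.26 log units; within the scatter), and the comparison with 2-(trifluoromethyl)phenyl gives a 1.1-fold lower number from compound 2 to compound 4 (0.06 log units; within the scatter). This place therefore accepts a ring with three methoxy groups, and that ring cannot be told apart in this test from either group it is compared with. No measurement bears on why these readings fall as they do. Still open, on these data alone, is how an aromatic ring carrying an amine or a carboxylic acid would read here. As far as these compounds go, a plain alkyl chain in place of the ring is equally open.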